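Chloro for methoxy on a sulfanyl chalcone series

A few compounds are considered here, and "the series" means these few. Any claim that something is new, unique, unknown or untested is made for them only; others in the source may bear on it.

Three compounds sharing a common core were tested in a functional assay on DU-145 cells (Homo sapiens) for inhibition, read by trypan blue exclusion, with a stated time of 96 h; a higher number here means a weaker inhibitor of growth, a lower number a stronger inhibitor of growth. Compound 1 `COc1ccc(/C=C(/Sc2ccc(C)cc2)C(=O)c2ccc(Br)cc2)cc1` gives 50000 nM. Compound 2 `Cc1ccc(S/C(=C/c2ccc(Cl)cc2)C(=O)c2ccc(Br)cc2)cc1`, which carries chloro in place of methoxy on an aromatic carbon, gives 10000 nM, a step of a 5.0-fold lower number from compound 1 to compound 2 (0.70 log units; beyond the scatter). Compound 3 `COc1ccc(/C=C(/SCc2ccc(Cl)cc2)C(=O)c2ccc(Br)cc2)cc1` has a core that differs from that of compound 1 by 4-chlorobenzyl in place of 4-methylphenyl on a sulfur; in the same assay compound 3 gives 10000 nM, a step of a 5.0-fold lower number from compound 1 to compound 3 (0.70 log units; beyond the scatter); compound 3 and compound 2 stand level within the scatter.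

Compound 4 `O=C(/C(=C\c1ccc(Cl)cc1)SCc1ccc(Cl)cc1)c1ccc(Br)cc1` is not yet measured. It carries chloro in place of methoxy on an aromatic carbon, the same change as that from compound 1 to compound 2. For the measured compounds named here, that earlier step, a 5.0-fold lower number from compound 1 to compound 2 (0.70 log units; beyond the scatter), is the only guide, so a step of similar but tempered size is expected, a 3.3-fold lower number from compound 3 to compound 4 (0.52 log units; beyond the scatter), because compound 3 starts at 10000 nM. Compound 4 is therefore estimated at 3000 nM, between 1000 nM and 15000 nM.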

Compound 4, concentration for 50% growth inhibition: 10000 nM
Compound 4: middle estimate off by 3.3-fold (0.52 log units), on the low side; low and high end bracket the measured number.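

In this assay, chloro in place of methoxy gave no change at the digits printed from compound 3 to compound 4 (within the scatter), so the step seen on the core of compound 1 did not carry over to the second core: the same change on two cores in this assay, a 5.0-fold lower number (0.70 log units; beyond the scatter) from compound 1 to compound 2 and no change at the digits printed (within the scatter) from compound 3 to compound 4, 5.0-fold (0.70 log units) apart, beyond the scatter of two such steps. The change of 4-methylphenyl to 4-chlorobenzyl on the sulfur likewise gave no change at the digits printed from compound 2 to compound 4 (within the scatter), unlike its step on the methoxy-bearing core: the same change on two cores in this assay, a 5.0-fold lower number (0.70 log units; beyond the scatter) from compound 1 to compound 3 and no change at the digits printed (within the scatter) from compound 2 to compound 4, 5.0-fold (0.70 log units) apart, beyond the scatter of two such steps. For the compounds shown here, the two changes therefore do not add up across these four compounds, but each has been seen on only two cores, which does not show why or how either would behave on another core.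

The compounds shown leave open how an amine or a carboxylic acid would read in place of the chloro. They also leave open whether a longer chain on the sulfur would shift the number from the level shared by compound 2, compound 3 and compound 4.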